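The source may hold more compounds than are shown below. What is called first, only, known or untested is meant among the compounds shown, and "the series" means these compounds.

Compound 1 `COc1ccc(-n2cnnc2-c2cc(OC)c(OC)c(OC)c2)cc1`: 290 nM
Compound 2 `COc1cc(-c2nncn2-c2ccc(N(C)C)cc2)cc(OC)c1OC`: 29.6 nM

In an ADME assay on HeLa cells (Homo sapiens) for cytotoxicity (a higher number here means a weaker inhibitor, a lower number a stronger inhibitor), compound 1 has the higher of the two measured numbers. Among the compounds with values here, the one measured step is a 9.8-fold lower number from compound 1 to compound 2 (0.99 log units; beyond the scatter), with dimethylamino in place of methoxy on an aromatic carbon.

Compound 3 `COc1ccc(-n2cnnc2-c2cc(OC)c(OC)c(OC)c2)cc1O` keeps all of compound 1 and changes one place: hydroxy in place of hydrogen on an aromatic carbon. This is hydroxy in place of hydrogen on an aromatic carbon, ortho to a methoxy group. Within the data shown here, no measured step makes this change, so the step above is only loose guidance. It does show that a single change to compound 1 can lower the number beyond the scatter, as seen in a 9.8-fold lower number from compound 1 to compound 2 (0.99 log units; beyond the scatter). A similar, somewhat smaller move is expected here, though with wide uncertainty. The expected step is a 6.4-fold lower number from compound 1 to compound 3 (0.81 log units; beyond the scatter). For compound 3 the estimated value is 45 nM, with an expected range of 8 nM to 250 nM.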

Compound 3, half-maximal inhibitory concentration: 25 nM
The estimate for compound 3 lay 1.8-fold (0.26 log units) above the measured number, and the stated range covers the measured number.
By their numbers in this assay, from the lowest: compounds 3 and 2 (each within the scatter of the next); then compound 1.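

In this assay, adding one hydroxy on an aromatic carbon, ortho to a methoxy group, gives a 12-fold lower number from compound 1 to compound 3 (1.06 log units; beyond the scatter). This shows that the methoxy group of compound 1 need not be replaced for the number to fall beyond the scatter: a place that held only a hydrogen also responds, and the group entering there has just 1 heavy atom. Nothing measured here gives a cause for this drop.

The compounds shown leave open whether hydroxy is needed at this place, or whether an amine, a fluorine or a second methoxy there would lower the number as well. They also leave open whether hydroxy at this place and the dimethylamino group of compound 2 would lower the number further together, as each change appears only on its own.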